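Iodo for bromo on the nitro analogue

The compounds below may be only part of what the source reports. "The series", "measured", "known", "first", "only" and "open" are said of these compounds alone.

Measured compounds:
compound 1 `Cc1nc(C#Cc2cc(Br)cc([N+](=O)[O-])c2)cs1` — 0.93 nM
compound 2 `Cc1nc(C#Cc2cc(Cl)cc(C#N)c2)cs1` — 0.127 nM
compound 3 `Cc1nc(C#Cc2cc(Br)cc(C#N)c2)cs1` — 0.106 nM

The three measured compounds share one core and differ only on the six-membered aromatic ring of carbon only. In an assay on HEK293 cells for displacement of a labelled ligand from metabotropic glutamate receptor 5 (Rattus norvegicus), read by scintillation counting (a higher number here means a weaker inhibitor, a lower number a stronger inhibitor), compound 1 gives 0.93 nM, compound 2 gives 0.127 nM and compound 3 gives 0.106 nM. Compound 1 has the highest number of the three: the step of an 8.8-fold lower number from compound 1 to compound 3 (0.94 log units; beyond the scatter) lies beyond the scatter, and the gap from compound 1 to compound 2 lies beyond it as well. The step of a 1.2-fold lower number from compound 2 to compound 3 (0.08 log units; within the scatter) lies within the scatter.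

Compound 4 `Cc1nc(C#Cc2cc(I)cc([N+](=O)[O-])c2)cs1` is not yet measured. Relative to compound 1 the change is iodo in place of bromo on an aromatic carbon. Among the compounds with values here, the only measured step that bears on this is the halogen exchange a 1.2-fold lower number from compound 2 to compound 3 (0.08 log units; within the scatter), which lies within the scatter; no iodo compound has been measured. A step within the scatter is therefore expected in this assay, if anything toward a lower number. For compound 4 the expected value is 0.8 nM (range 0.35 nM to 2 nM), corresponding to an expected step of a 1.2-fold lower number from compound 1 to compound 4 (0.07 log units; within the scatter).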

Compound 4, inhibition constant: 1.84 nM
The estimate for compound 4 lay 2.3-fold (0.36 log units) below the measured number; the range from low to high includes it.
By their numbers in this assay, from the lowest: compounds 3 and 2 (each within the scatter of the next); then compounds 1 and 4 (each within the scatter of the next).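

In this assay, iodo in place of bromo on the aromatic carbon meta to a nitro group gives a 2.0-fold higher number from compound 1 to compound 4 (0.30 log units; within the scatter), so this position takes iodine as well as bromine without a change that can be told from the scatter. Within the data shown here, the only earlier halogen exchange, a 1.2-fold lower number from compound 2 to compound 3 (0.08 log units; within the scatter), was chloro to bromo with a nitrile as the second group, so the result extends the same reading to a heavier halogen and to the nitro compounds. Nothing shown gives a reason for this tolerance.

Going by these compounds, whether the step of an 8.8-fold lower number from compound 1 to compound 3 (0.94 log units; beyond the scatter) from nitro to cyano carries over to the iodo compounds stays open. On these data alone, how an amine, a methoxy group or a carboxylic acid at the halogen position compares with the halogens also stays open.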